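Chloro for fluoro on a weak growth inhibitor

The source may report more compounds than this note shows. Statements on the series, on what has been measured and on what is new or still open speak of the compounds shown alone.

Values in a functional assay on U-251 cells (Homo sapiens) for inhibition, read by sulforhodamine B assay, with a stated time of 48 h; a higher number here means a weaker inhibitor of growth, a lower number a stronger inhibitor of growth:
- compound 1 `CCOC(=O)c1nn(-c2ccccc2)c(-c2ccc(F)cc2)c1CNC(C)(C)C`: > 632000 nM; > 579000 nM (2 entries)
- compound 2 `CCOC(=O)c1nn(-c2ccccc2)c(-c2ccc(Cl)cc2)c1CNC(C)(C)C`: 73800 nM; > 559000 nM (2 entries)
- compound 3 `CC(C)(C)NCc1c(C(=O)O)nn(-c2ccccc2)c1-c1ccc(F)cc1`: > 680000 nM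
- compound 4 `CC(C)(C)NCc1c(C(=O)O)nn(-c2ccccc2)c1-c1ccc(Cl)cc1`: not yet measured

Compound 3 has no single number, only a limit of the assay: the limit of > 680000 nM in this assay, at which 1 of the 3 values shown sits. Compound 1 likewise gives only limits, (the several entries of compound 1 in this assay, > 632000 nM; > 579000 nM (2 entries)). Compound 2 gives one number and one limit, (the several entries of compound 2 in this assay, 73800 nM; > 559000 nM (2 entries)).

Compound 4 carries chloro in place of fluoro on an aromatic carbon, para to a large group (chloro in place of fluoro on an aromatic carbon). For the measured compounds named here, no measured step shows what this change does, so no step beyond the scatter is expected in this assay, and a further limit is the likeliest report. The expected change is an at least 1.1-fold lower number from compound 3 to compound 4 (0.05 log units; that floor lies within the scatter). For compound 4 the estimate is 600000 nM, with an expected range from 100000 nM to 700000 nM.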

Compound 4, concentration for 50% growth inhibition: > 652000 nM
Compound 4 was reported as a limit; the forecaster's own chance of this, stated with the estimate: 80%; at least 1.0-fold (0.03 log units) between middle value and limit.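

Compound 3 and compound 4 are both reported only as limits in this assay, so no step can be read between them. The compounds shown leave open whether chloro in place of fluoro changes growth inhibition in this pair at all.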